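The source may hold more compounds than are shown below. What is called first, only, known or untested is meant among the compounds shown, and "the series" means these compounds.

In an ADME assay on MDCK cells (Canis lupus familiaris) for cytotoxicity, read by MTT assay, with a stated time of 48 h (a higher number here means that more compound is tolerated, a lower number that less compound is tolerated), three compounds built on the shared core of compound 1, `COc1ccc([C@H]2CC(C)(O)[C@@H]3CC[C@@H](C)C[C@H]3O2)cc1`, have been measured. Compound 1 gives 689000 nM. Compound 2, `C[C@@H]1CC[C@@H]2[C@@H](C1)O[C@@H](c1ccc(F)cc1)CC2(C)O`, gives 65000 nM. For compound 3, `C[C@@H]1CC[C@@H]2[C@@H](C1)O[C@@H](c1ccc([N+](=O)[O-])cc1)CC2(C)O`, the assay reports only a limit, > 982000 nM. On the numbers shown, compound 3 therefore stands at a limit rather than at a number. The changes on the aromatic ring show an 11-fold lower number from compound 1 to compound 2 (1.03 log units; beyond the scatter), an at least 1.4-fold higher number from compound 1 to compound 3 (0.15 log units; that floor lies within the scatter) and an at least 15-fold higher number from compound 2 to compound 3 (1.17 log units; beyond the scatter); the last two rest on (the limit of > 982000 nM in this assay, at which 1 of the 3 values shown sits).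

Compound 4, `C[C@@H]1CC[C@@H]2[C@@H](C1)O[C@@H](c1ccc([N+](=O)[O-])cc1)CC2(C)F`, differs from compound 3 in one place: fluoro in place of hydroxy on a saturated ring carbon. Going by the values given here, none of the measured steps touches this saturated ring carbon; each of them alters the group on the aromatic ring, so no measured step bears directly on this change. Without such a step, the expectation for compound 4 in this assay is no change beyond the scatter, that is a step that the limit leaves unreadable from compound 3 to compound 4. Compound 4 is accordingly estimated at 1000000 nM, with a range from 300000 nM to 3000000 nM.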

Compound 4, half-maximal cytotoxic concentration: > 976000 nM
Compound 4: only a limit was reported; the forecaster's own chance of this, stated with the estimate: 60%; the middle value does not contradict the limit.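

Going by these compounds alone, compound 3 and compound 4 each carry only a limit rather than a number, so no step between them can be read. The compounds shown leave open whether fluoro in place of hydroxy on this saturated ring carbon changes the read-out at all.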